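The source may report more compounds than this note shows. Statements on the series, on what has been measured and on what is new or still open speak of the compounds shown alone.

Three compounds that share one core and differ only in the aromatic ring on a saturated chain carbon bound to a sulfur have been tested in a functional assay on SW 1116 cells (Homo sapiens) for antiproliferative activity, read by MTT assay, with a stated time of 24 h; a higher number here means a weaker inhibitor, a lower number a stronger inhibitor. Compound 1 `Clc1cccc(CSc2nnc(-c3ccc4c(c3)OCCO4)n2-c2ccccc2)c1` gives 10600 nM, compound 2 `Cc1ccccc1CSc1nnc(-c2ccc3c(c2)OCCO3)n1-c1ccccc1` gives 12700 nM, and compound 3 `Cc1ccc(CSc2nnc(-c3ccc4c(c3)OCCO4)n2-c2ccccc2)cc1` gives 16200 nM. Compound 3 therefore stands level with the other two, as its gaps to them are small: a 1.3-fold higher number from compound 2 to compound 3 (0.11 log units; within the scatter) and a 1.5-fold higher number from compound 1 to compound 3 (0.18 log units; within the scatter). Both lie within the usual scatter of repeated measurements.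

The unmeasured compound 4 `Brc1ccc(CSc2nnc(-c3ccc4c(c3)OCCO4)n2-c2ccccc2)cc1` keeps all of compound 3 except one group: bromo in place of methyl on an aromatic carbon. It has bromo in place of methyl on an aromatic carbon, para to a large group. Within the data shown here, no measured pair makes exactly this exchange. The nearest evidence is the set of steps that alter the same aromatic ring, namely the two above and a 1.2-fold higher number from compound 1 to compound 2 (0.08 log units; within the scatter). All of them stay within the scatter, so these three compounds show no real separation. No step beyond the scatter is therefore expected in this assay, in either direction. The estimated change is a 1.4-fold lower number from compound 3 to compound 4 (0.13 log units; within the scatter). For compound 4 the expected value is 12000 nM, with an estimated range from 6000 nM to 23000 nM.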

Compound 4, half-maximal inhibitory concentration: 5810 nM
Compound 4: middle estimate off by 2.1-fold (0.32 log units), on the high side; measured number outside the range, below it.
By their numbers in this assay, from the lowest: compounds 4, 1, 2 and 3 (each within the scatter of the next, the first and the last beyond it).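

In this assay, among these compounds, the change at this position, on an aromatic carbon para to a large group, gives the first step beyond the scatter: bromo in place of methyl gives a 2.8-fold lower number from compound 3 to compound 4 (0.45 log units; beyond the scatter) as a modest gain. The 4-bromophenyl group also clears the scatter against 2-methylphenyl, with a 2.2-fold lower number from compound 2 to compound 4 (0.34 log units; beyond the scatter) on that exchange, but not against 3-chlorophenyl, with a 1.8-fold lower number from compound 1 to compound 4 (0.26 log units; within the scatter) leaving those two compounds level. The aromatic ring on the saturated chain carbon, which showed no real separation across the first three compounds, can therefore shift this number modestly, although compound 1 remains level with compound 4 and the series has not clearly separated into a single best member.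

Nothing in the data shown accounts for the step from methyl to bromo. From the compounds shown here alone, whether an amine, a carboxylic acid or a longer chain on this same aromatic carbon would push the number further down, leave it level or raise it remains open, as does whether the gain from bromo would carry over to a different cell line.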